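The source may report more compounds than this note shows. Statements on the series, on what has been measured and on what is new or still open speak of the compounds shown alone.

The series shares one core, varied only in the aryl group attached to the five-membered ring. Compound 1 `COc1ccc(Cl)cc1-n1ncc(-c2nnc(-c3ccc(C)c([N+](=O)[O-])c3)o2)c1C` gives 6.42 in a physicochemical assay for lipophilicity, using the shake flask method, measured as octanol-water partition (a lower number here means a more polar compound, a higher number a more lipophilic compound), the highest of the three numbers. Compound 2 `COc1ccc(Cl)cc1-n1ncc(-c2nnc(-c3ccc(F)cc3)o2)c1C` gives 4.26 in this assay, the lowest. Compound 3 `COc1ccc(Cl)cc1-n1ncc(-c2nnc(-c3cc(Cl)cc(Cl)c3)o2)c1C` gives 5.61 in this assay, which places it second highest: its nearest neighbour is compound 1, and the step of a number 0.81 log units lower from compound 1 to compound 3 (beyond the scatter) is beyond the scatter, while the step of a number 1.35 log units higher from compound 2 to compound 3 (beyond the scatter) is larger still.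

Compound 4 `COc1ccc(Cl)cc1-n1ncc(-c2nnc(-c3ccccc3)o2)c1C` differs from compound 3 in one place: phenyl in place of 3,5-dichlorophenyl on an aromatic carbon. The two steps that bear on this exchange are a number 1.35 log units higher from compound 2 to compound 3 (beyond the scatter) and a number 2.16 log units lower from compound 1 to compound 2 (beyond the scatter); in both, the compound carrying the 4-fluorophenyl group sits far below the compounds carrying the other aryl groups. A plain phenyl group resembles the 4-fluorophenyl group of compound 2 more than the 3,5-dichlorophenyl group of compound 3, so a large downward step is expected here, of about the size seen from compound 2 to compound 3 but in the opposite direction. For compound 4 the expected step is a number 1.41 log units lower from compound 3 to compound 4 (beyond the scatter), and the value is estimated at 4.2, within a range from 3.6 to 4.8.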

Compound 4, partition coefficient: 4.32
Compound 4: the middle estimate sits 0.12 log units below what was measured; measured number inside the range.
By their numbers in this assay, from the lowest: compounds 2 and 4 (each within the scatter of the next); then compound 3; then compound 1.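

In this assay, within the data shown here, replacing fluoro with hydrogen on the aryl group gives a number 0.06 log units higher from compound 2 to compound 4 (within the scatter) and so leaves the number unresolved between the 4-fluorophenyl and phenyl groups, which the earlier compounds could not show because none carried an unsubstituted phenyl group. The phenyl group now also serves as a common reference for the other two aryl groups on this aromatic carbon of the five-membered ring, with a number 1.29 log units lower from compound 3 to compound 4 (beyond the scatter) for the exchange of 3,5-dichlorophenyl and a number 2.10 log units lower from compound 1 to compound 4 (beyond the scatter) for the exchange of 4-methyl-3-nitrophenyl, so among these four compounds only the aryl groups with two substituents stand apart from phenyl, and the 4-fluorophenyl group does not. No measurement at hand accounts for the difference in size between these steps.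

The compounds shown do not separate the share of the methyl group from that of the nitro group in 4-methyl-3-nitrophenyl, nor the share of one chlorine from that of the second in 3,5-dichlorophenyl. From the compounds shown here alone, it also remains open how an amine or a carboxylic acid on the phenyl group, or a saturated chain in place of it, would fall in this order.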